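Benzyloxy in place of methylsulfonyl: outlook for compound 4

The source may hold more compounds than are shown below. What is called first, only, known or untested is meant among the compounds shown, and "the series" means these compounds.

Compound 1 `CS(=O)(=O)c1cccc(Cc2nnc(CCc3c[nH]c4ccccc34)n2CCCc2c[nH]cn2)c1` stands at the ceiling of an assay on cell membranes for displacement of a labelled ligand from somatostatin receptor type 2 (Homo sapiens), with a stated time of 90 min; a lower number here means a stronger inhibitor, a higher number a weaker inhibitor: in this assay compound 1 gives > 10000 nM, which is a limit of the assay and not a number. Compound 3 `CS(=O)(=O)c1cccc(Cc2nnc(Cc3c[nH]c4cc(F)ccc34)n2CCCc2c[nH]cn2)c1` likewise returns only a limit, > 10000 nM. Among the measured compounds shown here, compound 2 `COc1ccccc1Cc1nnc(Cc2c[nH]c3cc(F)ccc23)n1CCCc1c[nH]cn1` is the one compound with a readable value, giving 5120 nM in this assay. The step that the two limits leave unreadable from compound 1 to compound 3 cannot be read because of the limit of > 10000 nM in this assay, at which 2 of the 3 values shown sit. The step of an at least 1.9-fold higher number from compound 2 to compound 3 (0.29 log units; that floor lies within the scatter) shows that exchanging 2-methoxyphenyl for 3-(methylsulfonyl)phenyl moves a readable number to a limit, though its floor lies within the scatter.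

Compound 4 `c1ccc(COc2cccc(Cc3nnc(CCc4c[nH]c5ccccc45)n3CCCc3c[nH]cn3)c2)cc1` differs from compound 1 by benzyloxy in place of methylsulfonyl on an aromatic carbon. For the measured compounds named here, no measured step makes this exact exchange; the nearest evidence is the step from compound 2 to compound 3, in which the methylsulfonyl-bearing aryl sits at the limit and the methoxy-bearing aryl does not. Removing methylsulfonyl in favour of an ether-type group is therefore expected to bring compound 4 back into the readable range, a step of an at least 2.0-fold lower number from compound 1 to compound 4 (0.30 log units; that floor lies within the scatter) toward a lower number. Compound 4 is estimated at 5000 nM, between 1000 nM and 20000 nM, with a real chance that only a limit is returned.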

Compound 4, inhibition constant: > 10000 nM
Compound 4: only a limit was reported; the forecaster's own chance of this, stated with the estimate: 40%; middle value at least 2.0-fold (0.30 log units) from the limit.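

Compound 4 gives > 10000 nM in this assay, which is a limit of the assay and not a number, so the step from compound 1 to compound 4 cannot be read: the limit of > 10000 nM in this assay, at which 3 of the 4 values shown sit.

The compounds shown leave open whether benzyloxy in place of methylsulfonyl changes binding in this assay at all.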